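Methyl added on a side chain: clearance in liver microsomes

This account rests on a few compounds, and the source may have more. Where it says the series, first, only, none or still open, it means among the compounds named here.

Measured compounds:
compound 1, `Nc1ccc(S(=O)(=O)c2ccc(-c3ncc(C(O)(C(F)(F)F)C(F)(F)F)cc3C#CCO)cc2)cn1`, 36 mL.min-1.g-1;
compound 2, `C[C@H](O)C#Cc1cc(C(O)(C(F)(F)F)C(F)(F)F)cnc1-c1ccc(S(=O)(=O)c2ccc(N)nc2)cc1`, 29 mL.min-1.g-1;
compound 3, `CCNc1nc(S(=O)(=O)c2ccc(N)nc2)ccc1-c1ccc(C(C)(O)C(F)(F)F)cn1`, 42 mL.min-1.g-1.

All three were tested in an ADME assay (liver) for metabolic stability, with Liver microsome (Rattus norvegicus) as the target, using microsomes and NADPH, with a stated time of 30 min, at 37 degrees C, tested at 1 uM; on this read-out higher numbers stand for fast clearance and lower numbers for slow clearance. The structure of compound 1 and that of compound 3 share the same amino-pyridine sulfone part, but the difference between the two cores is not broken down here. Compound 2 differs from compound 1 by methyl in place of hydrogen on a saturated chain carbon bound to an oxygen on a saturated carbon and a triple-bonded carbon, and that change gave a 1.2-fold lower number from compound 1 to compound 2 (0.09 log units; within the scatter). In this assay compound 3 gives 42 mL.min-1.g-1, and compound 1 gives 36 mL.min-1.g-1, two numbers that lie within the scatter of each other.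

Compound 4, `CC(C)Nc1nc(S(=O)(=O)c2ccc(N)nc2)ccc1-c1ccc(C(C)(O)C(F)(F)F)cn1`, has not yet been measured. It differs from compound 3 by methyl in place of hydrogen on a saturated chain carbon bound to a nitrogen on an aromatic ring and a saturated chain carbon. Going by the values given here, this is the same kind of change as the one from compound 1 to compound 2, but the place is different: there the new methyl sat on a carbon bound to an oxygen and a triple-bonded carbon, here it sits on a carbon bound to a nitrogen on an aromatic ring. Since the earlier step of a 1.2-fold lower number from compound 1 to compound 2 (0.09 log units; within the scatter) stayed within the scatter, the expected step for compound 4 is a 1.1-fold lower number from compound 3 to compound 4 (0.02 log units; within the scatter). The estimate for compound 4 is therefore 40 mL.min-1.g-1, expected to fall between 22 mL.min-1.g-1 and 72 mL.min-1.g-1.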

Compound 4, intrinsic clearance in microsomes: 62 mL.min-1.g-1
Estimate against measurement, compound 4: 1.6-fold (0.19 log units) below; the range from low to high includes it.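

Adding the methyl gave a 1.5-fold higher number from compound 3 to compound 4 (0.17 log units; within the scatter) in this assay, so this step cannot be told apart from the differences seen between repeated measurements. The earlier step points the other way, but the two steps do not truly differ: the same change on two cores in this assay, a 1.2-fold lower number (0.09 log units; within the scatter) from compound 1 to compound 2 and a 1.5-fold higher number (0.17 log units; within the scatter) from compound 3 to compound 4, 1.8-fold (0.26 log units) apart, within the scatter of two such steps. For these two pairs, then, the change moved from one core to another without a clear effect on clearance, but this does not show that the methyl has no effect across the series, and two pairs, each with the methyl in a different place, are too few to support a general rule.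

The compounds shown leave open how clearance would respond to a longer chain, such as butyl, or to a cyclopropyl group in place of the isopropyl of compound 4. They also leave open whether the same methyl change would stay within the scatter on a further core.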